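A few compounds are considered here, and "the series" means these few. Any claim that something is new, unique, unknown or untested is made for them only; others in the source may bear on it.

Values so far in a functional assay on A549 cells (Homo sapiens) for cytotoxicity, read by MTT assay, with a stated time of 24 h; a higher number here means a weaker inhibitor, a lower number a stronger inhibitor:
compound 1 `C/C(=N\NC(=O)/C(C#N)=C/c1ccc(Br)cc1)c1c(O)c2ccc(O)cc2oc1=O` gives 11400 nM
compound 2 `C/C(=N\NC(=O)/C(C#N)=C/c1cccc(Br)c1)c1c(O)c2ccc(O)cc2oc1=O` gives 22200 nM

Compound 2 sits within the scatter of compound 1, and these two numbers are all the series offers so far. The next compound, compound 3 `C/C(=N\NC(=O)/C(C#N)=C/c1ccccc1Cl)c1c(O)c2ccc(O)cc2oc1=O`, carries 2-chlorophenyl in place of 3-bromophenyl on a double-bonded chain carbon bound to a double-bonded chain carbon is the change. Going by the values given here, one measured step bears on it, a 1.9-fold higher number from compound 1 to compound 2 (0.29 log units; within the scatter), which exchanged 4-bromophenyl for 3-bromophenyl and stayed within the scatter. Among the compounds with values here, no measured compound carries 2-chlorophenyl or chlorine, so this support is indirect. In this assay no step beyond the scatter is expected, and a 1.4-fold lower number from compound 2 to compound 3 (0.14 log units; within the scatter) is the estimated step. Compound 3 is estimated at 16000 nM with an expected range from 7000 nM to 35000 nM for repeat measurements.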

Compound 3, half-maximal inhibitory concentration: 14200 nM
Estimate against measurement, compound 3: 1.1-fold (0.05 log units) above; the measured number falls inside the stated range.
By their numbers in this assay, from the lowest: compounds 1, 3 and 2 (each within the scatter of the next).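

In this assay, the 2-chlorophenyl group on a double-bonded chain carbon bound to a double-bonded chain carbon gives a 1.6-fold lower number from compound 2 to compound 3 (0.19 log units; within the scatter) and a 1.2-fold higher number from compound 1 to compound 3 (0.10 log units; within the scatter). Going by these compounds alone, the earlier pair compared only two bromophenyl groups, whereas this result brings chlorine into the comparison, and 4-bromophenyl, 3-bromophenyl and 2-chlorophenyl all remain within the scatter of one another at this place. Nothing available on these compounds accounts for this close agreement.

The compounds shown leave open whether a phenyl group carrying an amine or a carboxylic acid, or a longer chain in place of the phenyl group, would produce a step beyond the scatter. They also do not separate the halogen from its place on the phenyl group, as both differ in each step to compound 3.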